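Swapping ethylamino for dimethylamino on the side chain

The source may hold more compounds than are shown below. What is called first, only, known or untested is meant among the compounds shown, and "the series" means these compounds.

In a functional assay on HeLa cells (Homo sapiens) for antiproliferative activity, read by MTT assay, with a stated time of 48 h (a lower number here means a stronger inhibitor, a higher number a weaker inhibitor), compound 1 `C=C(c1ccc2c(c1)C=CC(C)(C)O2)c1ccc(OC)cc1NC(=O)CO` gives 100 nM, compound 2 `C=C(c1ccc2c(c1)C=CC(C)(C)O2)c1ccc(OC)cc1NC(=O)CN` gives 160 nM, and compound 3 `C=C(c1ccc2c(c1)C=CC(C)(C)O2)c1ccc(OC)cc1NC(=O)CNCC` gives 1580 nM, the highest number of the three. Compound 4 `C=C(c1ccc2c(c1)C=CC(C)(C)O2)c1ccc(OC)cc1NC(=O)CN(C)C` has the same atoms as compound 3, joined differently: dimethylamino in place of ethylamino on a saturated chain carbon bound to a carbonyl carbon. Three measured steps give context. For the measured compounds named here, replacing hydroxy with amino gave a 1.6-fold higher number from compound 1 to compound 2 (0.20 log units; within the scatter), replacing hydroxy with ethylamino gave a 16-fold higher number from compound 1 to compound 3 (1.20 log units; beyond the scatter), and the closest precedent, ethyl in place of hydrogen on the amine nitrogen, gave a 9.9-fold higher number from compound 2 to compound 3 (0.99 log units; beyond the scatter). Dimethylamino also has no hydrogen-free parent among the measured compounds, so no measurement tests this swap directly, and most of that rise should persist. The expected step, a 1.6-fold lower number from compound 3 to compound 4 (0.20 log units; within the scatter), is small. For compound 4 the estimate is 1000 nM, with an expected range of 300 nM to 3000 nM.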

Compound 4, half-maximal inhibitory concentration: 640 nM
Beside the measured number, compound 4's estimate is 1.6-fold (0.19 log units) above it; measured number inside the range.
By their numbers in this assay, from the lowest: compounds 1 and 2 (each within the scatter of the next); then compound 4; then compound 3.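

In this assay, rearranging the same atoms from ethylamino to dimethylamino gives a 2.5-fold lower number from compound 3 to compound 4 (0.39 log units; beyond the scatter) with the count of hydrogen-bond donors on this group going down, so at this carbon the arrangement of the atoms matters, not just their number. Dimethylamino still does not return to the lower numbers: the swap from amino gives a 4.0-fold higher number from compound 2 to compound 4 (0.60 log units; beyond the scatter) and the swap from hydroxy gives a 6.4-fold higher number from compound 1 to compound 4 (0.81 log units; beyond the scatter) in the same assay. From the compounds shown here alone, how diethylamino or a pyrrolidine ring would behave on this carbon stays open. Nothing available explains the gap between these two isomers.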